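Dropping One Trifluoromethyl From the Urea Tail

The source may report more compounds than this note shows. Statements on the series, on what has been measured and on what is new or still open speak of the compounds shown alone.

Measured compounds:
compound 1 `O=C(Nc1cccc(-n2cc(-c3ccncc3)c(-c3cc(O)cc(Cl)c3)n2)c1)Nc1ccc(Cl)c(C(F)(F)F)c1`: 91%
compound 2 `COc1cc(Cl)cc(-c2nn(-c3cccc(NC(=O)Nc4cc(C(F)(F)F)cc(C(F)(F)F)c4)c3)cc2-c2ccncc2)c1`: 91%

In a functional assay on U-251 cells (Homo sapiens) for inhibition, read by sulforhodamine B assay, with a stated time of 48 h, tested at 0.1 uM (a higher number here means a weaker effect of the compound at the concentration tested, a lower number a stronger effect), compound 1 gives 91%, and compound 2 gives 91%. Compound 2 stands level with compound 1 at the digits shown; the gap between the two lies within the scatter, so neither can be called the stronger of the pair. Both numbers sit high on the scale, which means that at this concentration each compound leaves most of the cell signal intact and has only a weak effect.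

Compound 3 `COc1cc(Cl)cc(-c2nn(-c3cccc(NC(=O)Nc4cccc(C(F)(F)F)c4)c3)cc2-c2ccncc2)c1` has not yet been measured. It differs from compound 2 in a single place: hydrogen in place of trifluoromethyl on an aromatic carbon. The group is removed from an aromatic carbon of a six-membered aromatic ring of carbon only, meta to a trifluoromethyl group that stays in place.

For the measured compounds named here, no step between two measured compounds is known here, so there is no measured guide for the size of this change. With both measured values reading near the top of the scale, little room remains upward, and the expected step of a number 2 percentage points higher from compound 2 to compound 3 (within the scatter) is small and within the scatter. Compound 3 is expected to give about 93%, with a range from 80% to 105%.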

Compound 3, a percentage reported as activity, at one concentration (the size of the read-out at that concentration, not a potency): 93%
The estimate for compound 3 equals the measured number at the digits printed; measured number inside the range.
By their numbers in this assay, from the lowest: compounds 1, 2 and 3 (each within the scatter of the next).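

Swapping one trifluoromethyl for hydrogen on an aromatic carbon, meta to a trifluoromethyl group that stays in place, gives in this assay a number 2 percentage points higher from compound 2 to compound 3 (within the scatter), the only step between compounds that differ in one place here, so this change has no effect that can be read beyond the scatter. Four heavy atoms leave the urea tail and the read-out stays high, which means that the second trifluoromethyl makes no measurable difference to this weak effect, though a weak effect leaves little room to see any further weakening. No measurement is available that could explain this result.

The compounds shown leave open whether a different group on this same aromatic carbon, such as an amine or a carboxylic acid, would shift the read-out beyond the scatter. They also leave open what would happen if hydrogen replaced the remaining trifluoromethyl group, and whether the step would look the same at a higher test concentration, where the compounds might have a stronger effect.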